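This account rests on a few compounds, and the source may have more. Where it says the series, first, only, none or still open, it means among the compounds named here.

In a functional assay on MDA-MB-231 cells (Homo sapiens) for antiproliferative activity, read by sulforhodamine B assay, with a stated time of 72 h (on this read-out lower numbers stand for stronger inhibition and higher numbers for weaker inhibition), compound 1 (`CCCCS(=O)(=O)Nc1cc(-c2ccc3ncnc(NCCN(C)C)c3c2)cnc1OC`) gives 280 nM, compound 2 (`COc1ncc(-c2ccc3ncnc(NCCN(C)C)c3c2)cc1NS(C)(=O)=O`) gives 2320 nM, and compound 3 (`CCCCS(=O)(=O)Nc1cc(-c2ccc3ncnc(NCc4ccncc4)c3c2)cnc1OC`) gives 4320 nM. Compound 3 and compound 2 lie within the scatter of each other, and both stand well above compound 1. Compound 4 (`COc1ncc(-c2ccc3ncnc(NCc4ccncc4)c3c2)cc1NS(=O)(=O)c1ccc(F)cc1F`) differs from compound 3 only on the sulfonyl sulfur: 2,4-difluorophenyl in place of butyl on a sulfonyl sulfur. For the measured compounds named here, two measured steps bear on this change. With hydrogen in place of propyl at a chain carbon bound to the sulfonyl sulfur, the numbers show an 8.3-fold higher number from compound 1 to compound 2 (0.92 log units; beyond the scatter), so a smaller group at this end went with a higher number. The other step, a 15-fold higher number from compound 1 to compound 3 (1.19 log units; beyond the scatter), arises at the part that compound 4 shares with compound 3. Going by the values given here, no measured compound carries an aromatic ring on the sulfonyl sulfur, so the direction remains uncertain. The expected change in this assay is a modest move to a lower number, a 2.4-fold lower number from compound 3 to compound 4 (0.38 log units; beyond the scatter). Compound 4 is estimated at 1800 nM, with an expected range of 400 nM to 7000 nM.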

Compound 4, half-maximal inhibitory concentration: 9710 nM
Compound 4: middle estimate off by 5.4-fold (0.73 log units), on the low side; the whole stated range lies below it.
By their numbers in this assay, from the lowest: compound 1; then compounds 2 and 3 (each within the scatter of the next); then compound 4.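

In this assay, 2,4-difluorophenyl in place of butyl on the sulfonyl sulfur gives a 2.2-fold higher number from compound 3 to compound 4 (0.35 log units; beyond the scatter), so this first aromatic ring at the position, with 8 heavy atoms against 4, did not bring the number down. Butyl now stands on the lower-number side of both steps at this sulfonyl sulfur, the other being an 8.3-fold higher number from compound 1 to compound 2 (0.92 log units; beyond the scatter), although compound 1 and compound 2 carry (dimethylamino)methyl where compound 3 and compound 4 carry pyridin-4-yl. Nothing measured here accounts for the rise from butyl to 2,4-difluorophenyl.

The compounds shown leave open whether a plain phenyl ring or a longer chain such as hexyl on the sulfonyl sulfur would follow butyl or 2,4-difluorophenyl. They also leave open how 2,4-difluorophenyl behaves alongside (dimethylamino)methyl.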